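A few compounds are considered here, and "the series" means these few. Any claim that something is new, unique, unknown or untested is made for them only; others in the source may bear on it.

Measured compounds:
- Compound 1, `CCCc1n[nH]c2c(=O)n(NC(=O)c3ccccc3)c(-c3cccc([N+](=O)[O-])c3)nc12`: 28.8%
- Compound 2, `O=C(Nn1c(-c2cccc([N+](=O)[O-])c2)nc2c(-c3cccc(Cl)c3)n[nH]c2c1=O)c1ccccc1`: "not determined" (no result reported) in a functional assay on SK-OV-3 cells (Homo sapiens) for cytotoxicity, read by sulforhodamine B assay, with a stated time of 2 days, tested at 100 uM; a higher number here means more inhibition at the concentration tested (going by the name of the read-out), a lower number less inhibition
- Compound 3, `O=C(Nn1c(-c2cccc([N+](=O)[O-])c2)nc2c(-c3ccc(F)cc3)n[nH]c2c1=O)c1ccccc1`: 77.7%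

Among the two compounds with a number in this assay, compound 3 stands highest, and compound 1 is the nearest of them, with a step of a number 48.9 percentage points higher from compound 1 to compound 3 (beyond the scatter) separating the two. Among the compounds with values here, that step, 4-fluorophenyl in place of propyl on an aromatic carbon, is the only measured step in the set.

Compound 4, `O=C(Nn1c(-c2cccc([N+](=O)[O-])c2)nc2c(-c3ccco3)n[nH]c2c1=O)c1ccccc1`, differs from compound 3 in one place: furan-2-yl in place of 4-fluorophenyl on an aromatic carbon. Within the data shown here, no measured step covers the exchange of one aromatic ring for another, so the step from compound 1 to compound 3 bears on it only loosely: it shows that a six-membered aromatic ring at this position gives a far higher number than a propyl chain, but it says nothing about a five-membered aromatic ring with one oxygen. The expected step is therefore uncertain, and a modest decrease from compound 3 seems as likely as no change beyond the scatter. Compound 4 is estimated at 58%, with a range from 25% to 85%, which corresponds to an expected step of a number 19.7 percentage points lower from compound 3 to compound 4 (beyond the scatter).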

Compound 4, a percentage reported as inhibition, at one concentration (the size of the read-out at that concentration, not a potency): 17.9%
The estimate for compound 4 lay 40.1 percentage points above the measured number; measured number below the stated range.
By their numbers in this assay, from the lowest: compound 4; then compound 1; then compound 3.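

In this assay, an aromatic ring at this position does not by itself bring a high number: furan-2-yl in place of 4-fluorophenyl gives a large drop (a number 59.8 percentage points lower from compound 3 to compound 4 (beyond the scatter)). Furan-2-yl also falls short of the propyl chain (a number 10.9 percentage points lower from compound 1 to compound 4 (beyond the scatter)), so of the two aromatic rings shown, one stands above propyl and the other below it, and "ring versus chain" does not describe this position. No measurement here bears on why the two rings differ so widely.

The compounds shown leave open whether the higher number goes with the fluorine or with the six-membered ring itself, which a plain phenyl ring would separate. They also leave open how a thiophen-2-yl ring, with sulfur in place of the furan oxygen, or a chain longer than propyl would compare.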